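From 1-Carboxyethyl to 1-Carboxycyclopropyl on an Amide Nitrogen

The source may report more compounds than this note shows. Statements on the series, on what has been measured and on what is new or still open speak of the compounds shown alone.

Three compounds that share one core and differ only on an amide-type nitrogen have been measured in a functional assay on BXPC-3 cells (Homo sapiens) for antiproliferative activity, read by MTT assay, with a stated time of 24 h (on this read-out higher numbers stand for weaker inhibition and lower numbers for stronger inhibition), so far. Here compound 1 `CCn1c(C(=O)N[C@H](C)CO)ccc1C(CC)(CC)c1ccc(OCS(=O)(=O)c2ccccc2)c(C)c1` gives 10000 nM and compound 2 `CCn1c(C(=O)NCCCO)ccc1C(CC)(CC)c1ccc(OCS(=O)(=O)c2ccccc2)c(C)c1` gives 26600 nM while compound 3 `CCn1c(C(=O)N[C@@H](C)C(=O)O)ccc1C(CC)(CC)c1ccc(OCS(=O)(=O)c2ccccc2)c(C)c1` gives 20800 nM as its reading. Compound 3 therefore stands level with compound 2, as shown by a 1.3-fold lower number from compound 2 to compound 3 (0.11 log units; within the scatter) and the reading for compound 1 is the lowest of the three, as shown by a 2.1-fold higher number from compound 1 to compound 3 (0.32 log units; beyond the scatter) and by a 2.7-fold higher number from compound 1 to compound 2 (0.42 log units; beyond the scatter) as well.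

The next compound is compound 4 `CCn1c(C(=O)NC2(C(=O)O)CC2)ccc1C(CC)(CC)c1ccc(OCS(=O)(=O)c2ccccc2)c(C)c1` which keeps the shared core and carries 1-carboxycyclopropyl in place of 1-carboxyethyl on the same nitrogen (1-carboxycyclopropyl in place of 1-carboxyethyl on an amide-type nitrogen). For the measured compounds named here, no measured pair makes exactly this change, so the evidence is indirect. Going by the values given here, the three steps above are the only guide, and even the largest of them is modest. The carboxy group also stays in place. A large shift is therefore not expected, and the expected result is a 1.0-fold lower number from compound 3 to compound 4 (0.02 log units; within the scatter) in this assay with no clear direction. For compound 4 the estimated value is 20000 nM (expected range 9000 nM to 45000 nM).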

Compound 4, half-maximal inhibitory concentration: > 50000 nM
Compound 4 ended at the assay's limit; the forecaster's own chance of this, stated with the estimate: 10%; middle value at least 2.5-fold (0.39 log units) from the limit.
By their numbers in this assay, from the lowest: compound 1; then compounds 3 and 2 (each within the scatter of the next). At a limit, above all of these: compound 4.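

In this assay compound 4 gives > 50000 nM, which is a limit of the assay and not a number: the limit of > 50000 nM in this assay, at which 1 of the 4 values shown sits.

Putting 1-carboxycyclopropyl in place of 1-carboxyethyl on the amide-type nitrogen keeps the carboxy group, adds a three-membered non-aromatic ring of carbon only and removes the defined stereocentre, and it gives an at least 2.4-fold higher number from compound 3 to compound 4 (0.38 log units; beyond the scatter), so this position responds to more than the presence of a carboxy group. Set against the hydroxy-bearing amides, the same group gives an at least 5.0-fold higher number from compound 1 to compound 4 (0.69 log units; beyond the scatter) and an at least 1.8-fold higher number from compound 2 to compound 4 (0.27 log units; that floor lies within the scatter), so only the first of these two comparisons clearly separates the pair, while the second does not yet settle an order.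

As far as these compounds go, how far the true reading of compound 4 lies past the limit stays unknown, and so does the full size of each of these steps. The compounds shown also cannot separate the effect of the ring from that of losing the stereocentre, and they leave open what 1-(hydroxymethyl)cyclopropyl, or an amine in place of the carboxy group on the same ring, would give on this nitrogen.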